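Trimming a Methyl from an Acid-Bearing Amide Side Chain

The source may report more compounds than this note shows. Statements on the series, on what has been measured and on what is new or still open speak of the compounds shown alone.

Compound 1 `CCn1c(C(=O)NCC(=O)OC)ccc1C(CC)(CC)c1ccc(OCS(=O)(=O)c2ccccc2)c(C)c1`, compound 2 `CCn1c(C(=O)N[C@H](C)C(=O)OC)ccc1C(CC)(CC)c1ccc(OCS(=O)(=O)c2ccccc2)c(C)c1` and compound 3 `CCn1c(C(=O)N[C@@H](C)C(=O)O)ccc1C(CC)(CC)c1ccc(OCS(=O)(=O)c2ccccc2)c(C)c1` share one core and differ only in the chain carried on the amide nitrogen. In a functional assay on PC-3 cells (Homo sapiens) for antiproliferative activity, read by MTT assay, with a stated time of 24 h (on this read-out higher numbers stand for weaker inhibition and lower numbers for stronger inhibition), compound 1 gives > 50000 nM, which is a limit of the assay and not a number. Compound 2 likewise reaches only > 50000 nM in this assay, again a limit. Among the measured compounds shown here, compound 3 gives 16800 nM in this assay, the only true number among the three. Compound 3 differs from compound 2 by 1-carboxyethyl in place of 1-(methoxycarbonyl)ethyl on an amide-type nitrogen, and this gives an at least 2.9-fold lower number from compound 2 to compound 3 (0.47 log units; beyond the scatter); the same ester-to-acid contrast seen from compound 1 gives an at least 2.9-fold lower number from compound 1 to compound 3 (0.47 log units; beyond the scatter). The change hydrogen in place of methyl on a saturated chain carbon bound to an amide-type nitrogen and a carbonyl carbon gives a step that the two limits leave unreadable from compound 2 to compound 1, since both sit at the limit of > 50000 nM in this assay, at which 2 of the 3 values shown sit. Compound 4 `CCn1c(C(=O)NCC(=O)O)ccc1C(CC)(CC)c1ccc(OCS(=O)(=O)c2ccccc2)c(C)c1` carries the same change relative to compound 3: hydrogen in place of methyl on a saturated chain carbon bound to an amide-type nitrogen and a carbonyl carbon. Going by these compounds, because the corresponding change gave a step that the two limits leave unreadable from compound 2 to compound 1, its size is unknown, and for compound 4 the expected step is a 1.2-fold higher number from compound 3 to compound 4 (0.08 log units; within the scatter). The estimate for compound 4 in this assay is 20000 nM, with a likely span from 7000 nM to 50000 nM.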

Compound 4, half-maximal inhibitory concentration: 30100 nM
Compound 4: the middle estimate sits 1.5-fold (0.18 log units) below what was measured; low and high end bracket the measured number.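

Among the two acids, hydrogen in place of methyl on a saturated chain carbon bound to an amide-type nitrogen and a carbonyl carbon gives a 1.8-fold higher number from compound 3 to compound 4 (0.25 log units; within the scatter) in this assay, so this pair shows a step that does not stand out from the scatter. The same change in the methyl esters cannot be read, and neither can it be compared with the acid pair, because both esters stay out of range: the limit of > 50000 nM in this assay, at which 2 of the 4 values shown sit. The acid pair therefore shows the change in one setting only, and the two ester comparisons, an at least 1.6-fold lower number from compound 2 to compound 4 (0.22 log units; that floor lies within the scatter) and an at least 1.6-fold lower number from compound 1 to compound 4 (0.22 log units; that floor lies within the scatter), give floors that also lie within the scatter, so they do not show that compound 4 truly separates from either ester.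

Going by these compounds, whether a longer chain, such as ethyl in place of the methyl, would move the number beyond the scatter stays open. So does the effect of an amine in place of the carboxylic acid on this chain.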